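A few compounds are considered here, and "the series" means these few. Any claim that something is new, unique, unknown or untested is made for them only; others in the source may bear on it.

Notes on a small set of thiocarbonyl compounds tested in a functional assay on MCF7 cells (Homo sapiens) for antiproliferative activity, read by MTT assay, with a stated time of 72 h; a higher number here means a weaker inhibitor, a lower number a stronger inhibitor. Compound 1 `O=c1cc(CSC(=S)N2CCCC2)oc2cc(Cl)ccc12`, compound 3 `CC(C)N(C(=S)SCc1cc(=O)c2ccc(Cl)cc2o1)C(C)C` and compound 2 `CC(C)N(C(=S)SCc1oc2ccccc2c(=O)c1Cl)C(C)C` are measured; compound 4 `O=c1c(Cl)c(CSC(=S)N2CCCC2)oc2ccccc12` is not. In this assay compound 3 gives > 25000 nM, which is a limit of the assay and not a number. Compound 1 gives > 25000 nM, again a limit. Compound 2 gives > 40000 nM, also a limit. The change from compound 3 to compound 1 is pyrrolidin-1-yl in place of diisopropylamino on a thiocarbonyl carbon; the step it made, a step that the two limits leave unreadable from compound 3 to compound 1, cannot be read because both values sit at the limit of > 25000 nM in this assay, at which 2 of the 3 values shown sit. The same change, (pyrrolidin-1-yl in place of diisopropylamino on a thiocarbonyl carbon), separates compound 2 from compound 4; how the core of compound 2 differs from that of compound 3 is not broken down here. Because compound 2 sits at the limit of > 40000 nM in this assay, at which 1 of the 3 values shown sits, and the measured instance of the change gives no readable direction, the expected step is a number no higher from compound 2 to compound 4 (the limit leaves the size open), most likely ending at a limit again. Compound 4 is therefore estimated at 40000 nM, within a range from 15000 nM to 100000 nM.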

Compound 4, half-maximal inhibitory concentration: 2300 nM
Estimate against measurement, compound 4: 17-fold (1.24 log units) above; measured number outside the range, below it.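

In this assay, going by these compounds, pyrrolidin-1-yl in place of diisopropylamino on a thiocarbonyl carbon gives an at least 17-fold lower number from compound 2 to compound 4 (1.24 log units; beyond the scatter), so on the core of compound 2 this change goes with a large drop in the number, and the full size of that drop stays open. Compound 2 is a limit of the assay and not a number: the limit of > 40000 nM in this assay, at which 1 of the 4 values shown sits. On the core of compound 3 the same change leads to compound 1, and that step cannot be read, so the series does not show whether the drop carries over to a second core or holds for the core of compound 2 alone, because both compounds sit at one limit: the limit of > 25000 nM in this assay, at which 2 of the 4 values shown sit.

Open, on these data alone, is whether another cyclic amine on the thiocarbonyl carbon, such as piperidin-1-yl or morpholin-4-yl, would give a number like that of compound 4. Also open, as far as these compounds go, is whether a smaller open-chain group such as dimethylamino would do the same on that core.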